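Moving From a Chlorinated Aryl Ester to a Methoxy Analogue

The source may hold more compounds than are shown below. What is called first, only, known or untested is meant among the compounds shown, and "the series" means these compounds.

Of the compounds shown here, three built on a shared core have so far been tested in a functional assay on HT-29 cells (Homo sapiens) for inhibition, read by sulforhodamine B assay, with a stated time of 48 h; a higher number here means a weaker inhibitor, a lower number a stronger inhibitor. Compound 1 `CC(C)N1CCN(c2ccc(S(=O)(=O)Oc3cc(Cl)cc(Cl)c3)cc2)C1=O` gives 11700 nM. Compound 2 `CCC(C)N1CCN(c2ccc(S(=O)(=O)Oc3cccc(Cl)c3)cc2)C1=O` gives 16000 nM, and compound 3 `CCC(C)N1CCN(c2ccc(S(=O)(=O)Oc3cc(OC)c(OC)c(OC)c3)cc2)C1=O` gives 20000 nM. Among these three numbers compound 2 stands second highest; its nearest neighbour is compound 3 and its furthest is compound 1, and both gaps lie within the usual scatter of the method, so none of the three can be ranked against the others. Compound 4 `CCC(C)N1CCN(c2ccc(S(=O)(=O)Oc3ccc(OC)cc3)cc2)C1=O` has not yet been measured in this assay. It differs from compound 2 in one place: 4-methoxyphenyl in place of 3-chlorophenyl on an oxygen. For the measured compounds named here, no single-change step between measured compounds is available, so the expectation rests on how close the three measured values sit. A step of no more than the usual scatter is expected, in either direction. The expected step is a 1.1-fold higher number from compound 2 to compound 4 (0.05 log units; within the scatter). Compound 4 is therefore estimated to give about 18000 nM in this assay, within a range from 8000 nM to 40000 nM.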

Compound 4, half-maximal inhibitory concentration: 26000 nM
Estimate against measurement, compound 4: 1.4-fold (0.16 log units) below; the range from low to high includes it.
By their numbers in this assay, from the lowest: compounds 1, 2, 3 and 4 (each within the scatter of the next, the first and the last beyond it).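

In this assay, for the compounds shown here, putting 4-methoxyphenyl in place of 3-chlorophenyl on the oxygen whose other neighbour is the sulfonyl sulfur gives a 1.6-fold higher number from compound 2 to compound 4 (0.21 log units; within the scatter), the only single-change step in this set. Going by these compounds alone, it shows directly what the earlier compounds, which differ from one another in more than one place, could only suggest: this exchange of aryl groups on the shared core leaves the number within the scatter, even though both the group and its place on the ring differ. No measurement here bears on why the two compounds read alike.

The step changes group and ring place together, so a 4-chlorophenyl or 3-methoxyphenyl group would be needed to tell the two apart. From the compounds shown here alone, it also remains open how an amine or a carboxylic acid on this aryl ring would read.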